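The compounds below may be only part of what the source reports. "The series", "measured", "known", "first", "only" and "open" are said of these compounds alone.

Three compounds share one core and differ only in the group carried on the oxygen of the outer aromatic ring. Compound 1 `CCCOc1ccc(C(O)C2OC(=O)c3c(OC)cc(OC)cc32)cc1` gives 9260 nM in a functional assay on RAW264.7 cells (Mus musculus) for inhibition, read by Griess assay, with stated times of 1 h and 24 h; on this read-out higher numbers stand for weaker inhibition and lower numbers for stronger inhibition. Compound 2 `CCCCOc1ccc(C(O)C2OC(=O)c3c(OC)cc(OC)cc32)cc1` gives 1800 nM in this assay, the second highest of the three numbers; compound 3 `COc1cc(OC)c2c(c1)C(C(O)c1ccc(OCc3ccc(F)cc3)cc1)OC2=O` gives 760 nM in this assay.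

The next compound, compound 4 `COc1cc(OC)c2c(c1)C(C(O)c1ccc(OCc3ccc(C)cc3)cc1)OC2=O`, is compound 2 with one change: 4-methylphenyl in place of propyl on a saturated chain carbon bound to an oxygen on an aromatic ring.

The closest comparison already measured is the step of a 2.4-fold lower number from compound 2 to compound 3 (0.37 log units; beyond the scatter), where the same propyl is exchanged for a fluorine-bearing ring at the same place. Lengthening the chain alone gave a 5.1-fold lower number from compound 1 to compound 2 (0.71 log units; beyond the scatter), and going from the shortest chain straight to the ring gave a 12-fold lower number from compound 1 to compound 3 (1.09 log units; beyond the scatter). A ring in this position has so far always meant a lower number, so compound 4 is expected to move in the same direction as compound 3, by a modest step of about a 2.1-fold lower number from compound 2 to compound 4 (0.33 log units; beyond the scatter). For compound 4 the estimate is 850 nM, with a likely range of 350 nM to 2000 nM.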

Compound 4, half-maximal inhibitory concentration: 3120 nM
For compound 4 the middle estimate is 3.7-fold (0.56 log units) below the measured one; the whole stated range lies below it.
By their numbers in this assay, from the lowest: compound 3; then compounds 2 and 4 (each within the scatter of the next); then compound 1.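

In this assay, the step to the 4-methylphenyl group gives a 1.7-fold higher number from compound 2 to compound 4 (0.24 log units; within the scatter) and so shows that a ring in this place does not by itself separate a compound from the butyl chain of compound 2. The ring's own substituent counts: methyl in place of fluoro on an aromatic carbon gives a 4.1-fold higher number from compound 3 to compound 4 (0.61 log units; beyond the scatter) and ties the low number of compound 3 to the fluorine-bearing ring rather than to any ring. Compared with the shortest chain, the methyl-bearing ring still gives a 3.0-fold lower number from compound 1 to compound 4 (0.47 log units; beyond the scatter) and keeps a real difference from compound 1.

As far as these compounds go, whether chloro or methoxy in place of that fluoro, or a plain benzyl group, would fall nearer compound 3 or compound 4 stays open. Nothing available here explains why fluoro and methyl differ at this place.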